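Methoxy on the Benzoyl Ring: What to Expect

This account rests on a few compounds, and the source may have more. Where it says the series, first, only, none or still open, it means among the compounds named here.

Within the data shown here, compound 2 `O=C(Nc1c(C(O)(C(F)(F)F)C(F)(F)F)ccc2ccccc12)c1ccccc1` gives 44 nM in an assay on LtK cells with ATP-sensitive inward rectifier potassium channel 11 (Homo sapiens) as the target (on this read-out lower numbers stand for an effect already at smaller amounts and higher numbers for an effect only at larger amounts of compound), the lowest of the two numbers measured so far. Compound 1 `CCC(C)C(=O)Nc1c(C(O)(C(F)(F)F)C(F)(F)F)ccc2ccccc12` gives 177000 nM in this assay, and the step of a 4000-fold lower number from compound 1 to compound 2 (3.60 log units; beyond the scatter) is the only one recorded. Compound 3 `COc1cccc(C(=O)Nc2c(C(O)(C(F)(F)F)C(F)(F)F)ccc3ccccc23)c1` differs from compound 2 by methoxy in place of hydrogen on an aromatic carbon. That single recorded step exchanged the whole group on the carbonyl carbon and does not bear directly on adding a methoxy to the phenyl. A step within the usual scatter is therefore expected, a 1.1-fold lower number from compound 2 to compound 3 (0.04 log units; within the scatter). Compound 3 is estimated at 40 nM, between 12 nM and 130 nM.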

Compound 3, half-maximal effective concentration: 185 nM
Compound 3: middle estimate off by 4.6-fold (0.67 log units), on the low side; the measured number lies above the stated range.
By their numbers in this assay, from the lowest: compound 2; then compound 3; then compound 1.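

In this assay methoxy in place of hydrogen brings a 4.2-fold higher number from compound 2 to compound 3 (0.62 log units; beyond the scatter) and so shows that this aromatic carbon of the benzoyl ring does not take the change without cost. Even so, 3-methoxyphenyl in place of sec-butyl still brings a 960-fold lower number from compound 1 to compound 3 (2.98 log units; beyond the scatter) and keeps most of what the phenyl gained. Nothing measured here gives a reason for the rise. From the compounds shown here alone, whether a hydroxy, a chlorine or an amine on this carbon would move the number the same way stays open, as does methoxy on the other carbons of this ring.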